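Carbamate to Bromobenzamide: What Cytotoxicity to Expect

This account rests on a few compounds, and the source may have more. Where it says the series, first, only, none or still open, it means among the compounds named here.

Three compounds share one core. Compound 1 `CCN(CC)c1cc2[nH]c(C3CCCCC3)nc2cc1NC(=O)c1ccc(N(C)C)cc1` has no result in an ADME assay on Vero cells (Chlorocebus sabaeus) for cytotoxicity, read by resazurin assay, with a stated time of 3 days; a higher number here means a weaker inhibitor, a lower number a stronger inhibitor; its entry reads "not determined" (no result reported). Compound 2 `CCN(CC)c1cc2[nH]c(C3CCCCC3)nc2cc1NC(=O)OCCOCCOC` in this assay reaches only the limit of the assay, > 100 ug/mL, which is a ceiling rather than a number. Of the two entries shown, compound 2 therefore sits at the limit of > 100 ug/mL in this assay, at which 1 of the 2 values shown sits, and the other entry gives no number at all, so no step between measured compounds can be drawn. Compound 3 `CCN(CC)c1cc2[nH]c(C3CCCCC3)nc2cc1NC(=O)c1cccc(Br)c1` differs from compound 2 in one place: 3-bromophenyl in place of 2-(2-methoxyethoxy)ethoxy on a carbonyl carbon. For the measured compounds named here, with no measured step to lean on, the expectation in this assay is a modest move toward a lower number, beyond the usual scatter but not far below the ceiling. The estimated step is an at least 2.5-fold lower number from compound 2 to compound 3 (0.39 log units; beyond the scatter). Compound 3 is expected to give 40 ug/mL, within 10 ug/mL to 100 ug/mL.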

Compound 3, half-maximal inhibitory concentration: > 100 ug/mL
Compound 3 ended at the assay's limit; the forecaster's own chance of this, stated with the estimate: 40%; at least 2.5-fold (0.39 log units) between middle value and limit.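

Compound 2 and compound 3 both stop at a limit of this assay rather than at a number, so no step between them can be read: the limit of > 100 ug/mL in this assay, at which 2 of the 3 values shown sit.

What the compounds shown leave open is whether 3-bromophenyl in place of 2-(2-methoxyethoxy)ethoxy on a carbonyl carbon changes the reading at all.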